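A pyridine exchange in the series

The source may report more compounds than this note shows. Statements on the series, on what has been measured and on what is new or still open speak of the compounds shown alone.

In an ADME assay for permeability, using PAMPA, with a stated time of 4 h, at pH 7.4, tested at 100 uM (a lower number here means that the compound crosses the layer more slowly, a higher number that the compound crosses the layer faster), compound 3 (`Cc1nc2cc(-c3cccc(-c4ccncc4)c3)nn2c(-c2cc(F)c3c(c2C)CCCO3)c1[C@H](OC(C)(C)C)C(=O)O`) gives 488 nm/s, within the scatter of compound 1 (`Cc1ccccc1-c1cccc(-c2cc3nc(C)c([C@H](OC(C)(C)C)C(=O)O)c(-c4cc(F)c5c(c4C)CCCO5)n3n2)c1`) at 471 nm/s and of compound 2 (`COc1ccccc1-c1cccc(-c2cc3nc(C)c([C@H](OC(C)(C)C)C(=O)O)c(-c4cc(F)c5c(c4C)CCCO5)n3n2)c1`) at 765 nm/s. Compound 4 (`COc1ccc(-c2cccc(-c3cc4nc(C)c([C@H](OC(C)(C)C)C(=O)O)c(-c5cc(F)c6c(c5C)CCCO6)n4n3)c2)cn1`) carries 6-methoxypyridin-3-yl in place of pyridin-4-yl on an aromatic carbon, meta to a large group: 6-methoxypyridin-3-yl in place of pyridin-4-yl on an aromatic carbon.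

Among the compounds with values here, three measured steps bear on this change: a 1.0-fold higher number from compound 1 to compound 3 (0.02 log units; within the scatter), a 1.6-fold lower number from compound 2 to compound 3 (0.20 log units; within the scatter) and a 1.6-fold higher number from compound 1 to compound 2 (0.21 log units; within the scatter). All three are small and lie within the scatter, so no step beyond the scatter is expected in this assay. The expected step is a 1.2-fold higher number from compound 3 to compound 4 (0.09 log units; within the scatter), with no firm direction. Compound 4 is estimated at 600 nm/s, with an expected range of 300 nm/s to 1150 nm/s.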

Compound 4, apparent permeability: 514 nm/s
Estimate against measurement, compound 4: 1.2-fold (0.07 log units) above; measured number inside the range.
By their numbers in this assay, from the lowest: compounds 1, 3, 4 and 2 (each within the scatter of the next).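

Notes on the series: in this assay the methoxy on the pyridine brings no step beyond the scatter at this place on the carbon-only ring, with a 1.1-fold higher number from compound 3 to compound 4 (0.02 log units; within the scatter) against pyridin-4-yl. The same holds against the two substituted phenyl groups, with a 1.5-fold lower number from compound 2 to compound 4 (0.17 log units; within the scatter) and a 1.1-fold higher number from compound 1 to compound 4 (0.04 log units; within the scatter) on record. No measurement on hand gives a reason for this.

From the compounds shown here alone, whether an aliphatic amine such as piperidine, or a carboxylic acid on this ring, would give a step beyond the scatter remains open, as does whether a longer alkoxy chain on the pyridine would.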